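A few compounds are considered here, and "the series" means these few. Any claim that something is new, unique, unknown or untested is made for them only; others in the source may bear on it.

Going by the values given here, compound 2 `CO[C@@H]1[C@H](N(C)c2ncc(-c3c[nH]c4ccc(F)cc34)s2)C[C@H]2O[C@]1(C)n1c3ccccc3c3c4c(c5c6cc(Br)ccc6n2c5c31)C(=O)NC4` gives 960 nM in a functional assay on MV4-11 cells (Homo sapiens) for antiproliferative activity, read by CellTiter-Glo, with a stated time of 72 h (a lower number here means a stronger inhibitor, a higher number a weaker inhibitor), the higher of the two numbers measured so far; compound 1 `CO[C@@H]1[C@H](N(C)c2ncc(-c3c[nH]c4ccccc34)s2)C[C@H]2O[C@]1(C)n1c3ccccc3c3c4c(c5c6cc(Br)ccc6n2c5c31)C(=O)NC4` gives 360 nM in this assay. The pair shows a 2.7-fold higher number from compound 1 to compound 2 (0.43 log units; beyond the scatter). Compound 3 `CO[C@@H]1[C@H](N(C)c2ncc(-c3c[nH]c4ccc(Cl)cc34)s2)C[C@H]2O[C@]1(C)n1c3ccccc3c3c4c(c5c6cc(Br)ccc6n2c5c31)C(=O)NC4` differs from compound 2 by chloro in place of fluoro on an aromatic carbon. Among the compounds with values here, no measured step exchanges one halogen for another, so the only guide is the size of the substituent step already seen, and that gives no direction for this one. For compound 3 a step of a 1.0-fold higher number from compound 2 to compound 3 (0.02 log units; within the scatter) is therefore expected, not beyond the scatter. Compound 3 is estimated at 1000 nM, with a range of 400 nM to 2600 nM.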

Compound 3, half-maximal inhibitory concentration: 700 nM
Estimate against measurement, compound 3: 1.4-fold (0.15 log units) above; the range from low to high includes it.
By their numbers in this assay, from the lowest: compounds 1, 3 and 2 (each within the scatter of the next, the first and the last beyond it).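

In this assay, 5-chloro-1H-indol-3-yl in place of 5-fluoro-1H-indol-3-yl gives a 1.4-fold lower number from compound 2 to compound 3 (0.14 log units; within the scatter), so these two halogens cannot be told apart at this position. Chloro in place of hydrogen gives a 1.9-fold higher number from compound 1 to compound 3 (0.29 log units; within the scatter), so, unlike the fluoro step from hydrogen, this one cannot be separated from the unsubstituted indole. No evidence here explains these results.

From the compounds shown here alone, whether a methoxy group, an amine or a carboxylic acid on this same aromatic carbon would give a number clearly apart from those of compound 1 and compound 3 remains open.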